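From Cyclopropylmethyl to Isobutyl on the Chloro Core

The source may hold more compounds than are shown below. What is called first, only, known or untested is meant among the compounds shown, and "the series" means these compounds.

Compound 1 `N#Cc1c(N2CCC(c3ccccc3)CC2)ccn(CC2CC2)c1=O` gives 3 mg/kg in a functional assay on the whole organism (strain Sprague-Dawley) for positive allosteric modulation, with Rattus norvegicus as the target, with a stated time of 20 h; a higher number here means that more compound is needed for the effect, a lower number that less compound is needed. Compound 2 `O=c1c(Cl)c(N2CCC(c3ccccc3)CC2)ccn1CC1CC1` reaches only the limit of this assay, > 10 mg/kg. Going by the values given here, the single measured step, an at least 3.3-fold higher number from compound 1 to compound 2 (0.52 log units; beyond the scatter), puts chloro in place of cyano on an aromatic carbon, and the limit of > 10 mg/kg in this assay, at which 1 of the 2 values shown sits, is all that fixes where compound 2 stands on the scale. Compound 3 `CC(C)Cn1ccc(N2CCC(c3ccccc3)CC2)c(Cl)c1=O` differs from compound 2 in one place: isopropyl in place of cyclopropyl on a saturated chain carbon bound to an aromatic nitrogen. Among the compounds with values here, no measured pair covers a change of this kind; the chloro-for-cyano step sits at a different place and says nothing about the group on the saturated chain carbon bound to the aromatic nitrogen. The step that the limit leaves unreadable from compound 2 to compound 3 is therefore expected to lie within the scatter. Compound 3 is estimated at 15 mg/kg, in the range 6 mg/kg to 40 mg/kg, and a bare limit is again the most likely report.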

Compound 3, minimum effective dose: 3 mg/kg
Compound 3: the middle estimate sits 5.0-fold (0.70 log units) above what was measured; measured number below the stated range.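

On the chloro core, the group on the saturated chain carbon bound to the aromatic nitrogen proves to matter in this assay: isopropyl in place of cyclopropyl gives an at least 3.3-fold lower number from compound 2 to compound 3 (0.52 log units; beyond the scatter). The earlier compounds had shown a change only at the aromatic carbon, so this is the first measured sign that the chain at this other place also shifts the dose, and that the ring of cyclopropyl is not needed for an effect. Compound 2 stands at a limit, so the step has a lower bound but no known full size: the limit of > 10 mg/kg in this assay, at which 1 of the 3 values shown sits.

As far as these compounds go, whether the same change would shift the dose on the cyano core of compound 1 remains open. So does what a longer chain, a benzyl group or a chain bearing an amine would do at this place.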